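The source may hold more compounds than are shown below. What is called first, only, known or untested is meant among the compounds shown, and "the series" means these compounds.

Working notes on the series. The shared core is shown in compound 1 `O=C1N=C(N2N=C(c3ccccc3)CC2c2ccccc2O)S/C1=C1/C(=O)Nc2ccccc21`. Among the measured compounds shown here, in a functional assay on cells (Leukemia cell, Homo sapiens) for cytotoxicity, read by sulforhodamine B assay, with a stated time of 48 h (on this read-out lower numbers stand for stronger inhibition of growth and higher numbers for weaker inhibition of growth), compound 1 gives 3190 nM, the second highest of the three numbers measured so far. Compound 2 `O=C1N=C(N2N=C(c3ccccc3)CC2c2ccccc2O)S/C1=C1/C(=O)Nc2ccc(Br)cc21` gives 270 nM; the step from compound 1 to compound 2 a 12-fold lower number from compound 1 to compound 2 (1.07 log units; beyond the scatter) rests on a bromo in place of hydrogen on an aromatic carbon. Compound 3 `COc1ccc(C2CC(c3ccc4ccccc4c3)=NN2C2=NC(=O)/C(=C3\C(=O)Nc4ccccc43)S2)cc1` gives 17500 nM; it differs from compound 1 in more than one place, so no single step can be read from that pair.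

Compound 4 `O=C1N=C(N2N=C(c3ccccc3)CC2c2ccc(Cl)cc2)S/C1=C1/C(=O)Nc2ccccc21` is not yet measured. It differs from compound 1 by 4-chlorophenyl in place of 2-hydroxyphenyl on a saturated ring carbon. For the measured compounds named here, no measured step touches this saturated ring carbon: the only single step, from compound 1 to compound 2, sits on an aromatic carbon elsewhere in the core, and its large size says nothing about the present change. The higher number of compound 3 comes with two changes at once and cannot be assigned to this position alone. Compound 4 is therefore expected to stay near compound 1, estimated at 4000 nM with a range from 1300 nM to 13000 nM. The expected step from compound 1 to compound 4 is a 1.3-fold higher number from compound 1 to compound 4 (0.10 log units; within the scatter), not clearly beyond the scatter.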

Compound 4, concentration for 50% growth inhibition: 370 nM
Compound 4: the middle estimate sits 11-fold (1.03 log units) above what was measured; the whole stated range lies above it.
By their numbers in this assay, from the lowest: compounds 2 and 4 (each within the scatter of the next); then compound 1; then compound 3.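

At the saturated ring carbon of the five-membered non-aromatic ring, the change to 4-chlorophenyl in place of 2-hydroxyphenyl gives in this assay an 8.6-fold lower number from compound 1 to compound 4 (0.94 log units; beyond the scatter), the first measured sign that this position bears on growth inhibition. Compound 4 has 0 hydrogen-bond donors in the entering group, against 1 in the group that leaves, so the hydroxy group of 2-hydroxyphenyl is not required for a low number in this series. No measurement shown gives a cause for this step.

The step changes the substituent and its place on the phenyl ring at once, so the parts played by losing the hydroxy group and gaining chlorine stay unseparated. From the compounds shown here alone, an unsubstituted phenyl, 2-chlorophenyl or 4-hydroxyphenyl at this carbon would separate them, and whether the bromo step carries over onto compound 4 also remains open.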